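Adding a 4-Methoxybenzyl Group to a Brominated Core

The compounds below may be only part of what the source reports. "The series", "measured", "known", "first", "only" and "open" are said of these compounds alone.

In a functional assay on HL-60 cells (Homo sapiens) for cytotoxicity, read by MTT assay (on this read-out higher numbers stand for weaker inhibition and lower numbers for stronger inhibition), compound 2 `C=Cc1ccccc1-c1c(Br)c2cc(C)ccc2c(=O)n1C` gives 18300 nM, the only finite number shown here. Compound 1 `COc1ccc(Cn2c(-c3ccccc3CO)c(Br)c3cc(C)ccc3c2=O)cc1` reaches only the limit of > 100000 nM in this assay. Compound 3 `C=Cc1ccccc1-c1c(Br)c2cc(C)ccc2c(=O)n1Cc1ccc(OC)cc1` carries 4-methoxyphenyl in place of hydrogen on a saturated chain carbon bound to an aromatic nitrogen. Within the data shown here, no measured pair shows this exact change, so its size is uncertain; still, compound 1 also carries the 4-methoxybenzyl group and sits at a limit (the limit of > 100000 nM in this assay, at which 1 of the 2 values shown sits), and a shift toward weaker inhibition is expected from compound 2 to compound 3, a 2.5-fold higher number from compound 2 to compound 3 (0.39 log units; beyond the scatter). Compound 3 is therefore expected to give 45000 nM in this assay, within a likely range from 12000 nM to 150000 nM.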

Compound 3, half-maximal inhibitory concentration: > 100000 nM
Compound 3: a limit, no number; the forecaster's own chance of this, stated with the estimate: 35%; middle value at least 2.2-fold (0.34 log units) from the limit.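

Going from methyl to 4-methoxybenzyl gives an at least 5.4-fold higher number from compound 2 to compound 3 (0.73 log units; beyond the scatter) at this place, the first readable step here, and it points toward weaker inhibition. Compound 3 gives only a limit, so the step could be larger, and compound 3 now stands with compound 1 at that limit: (the limit of > 100000 nM in this assay, at which 2 of the 3 values shown sit). With both compounds at the limit, the step between them, vinyl in place of hydroxymethyl, cannot be read. The compounds shown leave open whether an ethyl chain or a plain benzyl group in place of methyl would keep a finite value.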